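A few compounds are considered here, and "the series" means these few. Any claim that something is new, unique, unknown or untested is made for them only; others in the source may bear on it.

Measured compounds:
compound 1 `O=c1cc(Cn2cc(C3CC3)nn2)c2ccc(O)cc2o1` — > 100000 nM
compound 2 `CC(O)c1cn(Cc2cc(=O)oc3cc(O)ccc23)nn1` — > 100000 nM
compound 3 `CCCCc1ccc(-c2cn(Cc3cc(=O)oc4cc(O)ccc34)nn2)cc1` — 48400 nM

In a functional assay on HepG2 cells (Homo sapiens) for inhibition, read by MTT assay, with a stated time of 72 h (a lower number here means a stronger inhibitor, a higher number a weaker inhibitor), compound 1 reaches only a limit, > 100000 nM. Compound 2 likewise reaches only a limit in this assay, > 100000 nM. The step from compound 1 to compound 2, 1-hydroxyethyl in place of cyclopropyl on an aromatic carbon, is therefore a step that the two limits leave unreadable from compound 1 to compound 2. Within the data shown here, compound 3 gives 48400 nM in this assay and is the only compound of the three with a number; the other two sit at the limit of > 100000 nM in this assay, at which 2 of the 3 values shown sit.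

Compound 4 `CCCC1CCC(c2ccc(-c3cn(Cc4cc(=O)oc5cc(O)ccc45)nn3)cc2)CC1` differs from compound 3 by 4-propylcyclohexyl in place of butyl on an aromatic carbon. Among the measured compounds shown here, no measured step concerns this position or this kind of exchange, and the one measured step is unreadable, so nothing in the numbers sets a direction or size for the change. The expectation for compound 4 rests on compound 3 alone, with 48400 nM as anchor, and a step of a 1.4-fold lower number from compound 3 to compound 4 (0.14 log units; within the scatter) is estimated, within the scatter. Compound 4 is thus expected at about 35000 nM, ranging from 10000 nM to 100000 nM, with a fair chance that only a limit is returned.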

Compound 4, half-maximal inhibitory concentration: 30400 nM
Compound 4: middle estimate off by 1.2-fold (0.06 log units), on the high side; low and high end bracket the measured number.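

In this assay, 4-propylcyclohexyl in place of butyl on the aromatic carbon gives a 1.6-fold lower number from compound 3 to compound 4 (0.20 log units; within the scatter). Among these compounds, this is the first readable step: an open chain at this position can give way to a larger group with a six-membered non-aromatic ring of carbon only, and no change beyond the scatter follows, so this exchange does not separate the two compounds. Compound 1 and compound 2, which carry neither of these groups, remain at a limit, and the step between them cannot be read: the limit of > 100000 nM in this assay, at which 2 of the 4 values shown sit.

The compounds shown leave open what an amine, a carboxylic acid or a chain longer than butyl would do on this aromatic carbon. They also leave open whether any group at this position can move the number in this assay beyond the scatter.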